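Swapping the aryl group on a spiro-fused diaminotriazine ether chain

The source may report more compounds than this note shows. Statements on the series, on what has been measured and on what is new or still open speak of the compounds shown alone.

Compound 1 `COc1ccc(OCCCON2C(N)=NC(N)=NC23CCOCC3)cc1` carries a 4-methoxyphenyl ether at the end of the chain. In a functional assay on HepG2 cells (Homo sapiens) for antiproliferative activity, read by MTT assay, with a stated time of 72 h (on this read-out lower numbers stand for stronger inhibition and higher numbers for weaker inhibition), compound 1 gives "not determined" (no result reported), so there is no number for compound 1 to anchor this step.

The change to compound 4 `NC1=NC2(CCOCC2)N(OCCCOc2cccc(Cl)c2)C(N)=N1` is 3-chlorophenyl in place of 4-methoxyphenyl on an oxygen on a saturated carbon.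

Two measured compounds share the chain and aryl ether pattern but have a different spiro ring atom. Compound 2 `NC1=NC2(CCSCC2)N(OCCCOc2cccc(Cl)c2)C(N)=N1` gives 90 nM in this assay. Compound 3 `NC1=NC2(CCSCC2)N(OCCCOc2ccc(Br)cc2)C(N)=N1` gives 1400 nM in this assay. Going by the values given here, the one measured step is a 16-fold higher number from compound 2 to compound 3 (1.19 log units; beyond the scatter), which shows that the aryl group alone can move the number a long way. Among the compounds with values here, compound 4 carries the same 3-chlorophenyl as compound 2 and differs from it only in the spiro ring, a change for which no measured step exists, so the expectation rests mainly on compound 2 and its value 90 nM.

Compound 4 is therefore expected to give about 200 nM in this assay, with a range from 40 nM to 1500 nM to allow for the unmeasured ring change.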

Compound 4, half-maximal inhibitory concentration: 150 nM
Compound 4: middle estimate off by 1.3-fold (0.12 log units), on the high side; measured number inside the range.
By their numbers in this assay, from the lowest: compounds 2 and 4 (each within the scatter of the next); then compound 3.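

In this assay, going by these compounds alone, compound 1 gives "not determined" (no result reported), so the change from compound 1 to compound 4 yields no step that can be read. The compounds shown leave open what 3-chlorophenyl in place of 4-methoxyphenyl does to the number on this core. Nothing available here bears on the result for compound 4.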